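The source may report more compounds than this note shows. Statements on the series, on what has been measured and on what is new or still open speak of the compounds shown alone.

Compound 1 `COc1ccc2nc(C)cc(OCC(=O)Nc3ccc(F)cc3)c2c1`: in a toxicity assay on HepG2 cells (Homo sapiens) for inhibition, read by CellTiter-Glo, with a stated time of 48 h (a lower number here means a stronger inhibitor, a higher number a weaker inhibitor), compound 1 gives 63100 nM.
Compound 2 `COc1ccc2nc(C)cc(OCC(=O)Nc3ccncc3)c2c1`: in this assay compound 2 gives > 100000 nM, which is a limit of the assay rather than a number.

Compound 2 thus stands at the limit, where one of the two values shown sits (the limit of > 100000 nM in this assay, at which 1 of the 2 values shown sits). Compound 3 `COc1ccc2nc(C)cc(OCC(=O)Nc3noc(C)c3C)c2c1` carries 4,5-dimethyl-1,2-oxazol-3-yl in place of pyridin-4-yl on an amide-type nitrogen. For the measured compounds named here, the only measured step at this position is an at least 1.5-fold higher number from compound 1 to compound 2 (0.19 log units; that floor lies within the scatter), whose floor lies within the scatter; no step beyond the scatter is expected for compound 3 in this assay. Compound 3 is expected to stay near the limit, with an estimated change of a number no higher from compound 2 to compound 3 (the limit leaves the size open). The estimate for compound 3 is 100000 nM, ranging from 40000 nM to 300000 nM.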

Compound 3, half-maximal inhibitory concentration: > 100000 nM
Compound 3: no number, only a limit; the forecaster's own chance of this, stated with the estimate: 70%; the middle value lies on the limit itself.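

In this assay compound 3 gives > 100000 nM, which is a limit of the assay. With 4,5-dimethyl-1,2-oxazol-3-yl in place of 4-fluorophenyl, the result is an at least 1.5-fold higher number from compound 1 to compound 3 (0.19 log units; that floor lies within the scatter), and the step between the two limits cannot be read. A five-membered aromatic ring on the amide-type nitrogen thus reads the same as pyridin-4-yl, and the series now collects at one ceiling: the limit of > 100000 nM in this assay, at which 2 of the 3 values shown sit.

As far as these compounds go, how far compound 2 and compound 3 lie past the limit stays open. Also open, from the compounds shown here alone, is whether a carboxylic acid or an aminomethyl group on the phenyl ring would shift the number relative to compound 1.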